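A few compounds are considered here, and "the series" means these few. Any claim that something is new, unique, unknown or untested is made for them only; others in the source may bear on it.

The series shares one core and differs only in the aryl group on the piperazine. In a functional assay on the whole organism (strain CD-1) with Mus musculus as the target, in the maximal electroshock model, with a stated time of 0.5 h (a higher number here means that more compound is needed for the effect, a lower number that less compound is needed), compound 1 `CC1(c2ccccc2)CC(=O)N(CC(=O)N2CCN(c3ccccc3F)CC2)C1=O` gives 100 mg/kg. For the measured compounds named here, compound 2 `COc1cccc(N2CCN(C(=O)CN3C(=O)CC(C)(c4ccccc4)C3=O)CC2)c1` stands apart: in this assay compound 2 is recorded as "not active" (no number reported), so no dose can be set beside the value of compound 1, and no step to any other compound can be counted for it. Compound 3 `CC1(c2ccccc2)CC(=O)N(CC(=O)N2CCN(c3ccccc3)CC2)C1=O` is not yet measured. It differs from compound 2 by hydrogen in place of methoxy on an aromatic carbon. Going by the values given here, since compound 2 carries no number, the size of the step cannot be stated; the expectation is only that compound 3 will show an effect at a measurable dose, in the direction of less compound needed than for compound 2, though a report of no activity remains possible. In this assay compound 3 is expected to give about 100 mg/kg, within a range of 30 mg/kg to 300 mg/kg.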

Compound 3, minimum effective dose: 300 mg/kg
Compound 3: middle estimate off by 3.0-fold (0.48 log units), on the low side; the range from low to high includes it.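

In this assay, for the compounds shown here, the step with hydrogen in place of fluoro on an aromatic carbon is a 3.0-fold higher number from compound 1 to compound 3 (0.48 log units; beyond the scatter), so for the first time one change can be sized, and it lies beyond the usual scatter, with the fluoro compound needing less. The bare phenyl of compound 3 still has an effect at a measurable dose, 300 mg/kg, while compound 2 with its 3-methoxyphenyl group has none on record, and the step between these two cannot be read. Nothing given here accounts for either difference.

On these data alone, whether chloro or an amine in place of fluoro would give a dose nearer that of compound 1 or that of compound 3 remains open. So does whether hydroxy in place of methoxy would bring a measurable dose back.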